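Phenyl for benzyl on the thiourea nitrogen

The source may report more compounds than this note shows. Statements on the series, on what has been measured and on what is new or still open speak of the compounds shown alone.

Compound 3 `S=C(NCc1ccccc1)N/N=C/c1ccc2ccccc2n1` gives 21900 nM in a functional assay on HL-60 cells (Homo sapiens) for antiproliferative activity, read by sulforhodamine B assay, with a stated time of 72 h (on this read-out lower numbers stand for stronger inhibition and higher numbers for weaker inhibition), the lowest of the two numbers in hand. Compound 2 `Cc1ccc(NC(=S)N/N=C/c2ccc3ccccc3n2)cc1` gives 78300 nM, and the step is a 3.6-fold lower number from compound 2 to compound 3 (0.55 log units; beyond the scatter). For compound 1 `Fc1ccccc1NC(=S)N/N=C/c1ccc2ccccc2n1` the value > 100000 nM is a limit of the assay and not a number (the limit of > 100000 nM in this assay, at which 1 of the 3 values shown sits). From there the steps are an at least 4.5-fold lower number from compound 1 to compound 3 (0.65 log units; beyond the scatter) and an at least 1.2-fold lower number from compound 1 to compound 2 (0.10 log units; that floor lies within the scatter).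

Compound 4 `S=C(N/N=C/c1ccc2ccccc2n1)Nc1ccccc1` differs from compound 3 thus: phenyl in place of benzyl on an amide-type nitrogen. Among the compounds with values here, the steps that bear on it, a 3.6-fold lower number from compound 2 to compound 3 (0.55 log units; beyond the scatter) and an at least 4.5-fold lower number from compound 1 to compound 3 (0.65 log units; beyond the scatter), each put benzyl in place of 4-methylphenyl or 2-fluorophenyl and lowered the number; the present change runs the other way, so a modest rise is expected, a 2.7-fold higher number from compound 3 to compound 4 (0.44 log units; beyond the scatter). Compound 4 is therefore estimated at 60000 nM (range 25000 nM to 120000 nM).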

Compound 4, half-maximal inhibitory concentration: 9130 nM
Beside the measured number, compound 4's estimate is 6.6-fold (0.82 log units) above it, outside the stated range (below it).
By their numbers in this assay, from the lowest: compound 4; then compound 3; then compound 2. At a limit, above all of these: compound 1.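

In this assay, benzyl is not the best of the groups shown on this nitrogen: phenyl in its place gives a 2.4-fold lower number from compound 3 to compound 4 (0.38 log units; beyond the scatter). Both ring substituents shown also sit above the unsubstituted phenyl, with hydrogen in place of methyl giving an 8.6-fold lower number from compound 2 to compound 4 (0.93 log units; beyond the scatter) and hydrogen in place of fluoro giving an at least 10-fold lower number from compound 1 to compound 4 (1.03 log units; beyond the scatter). Compound 1 stands at a limit of the assay, not a number: the limit of > 100000 nM in this assay, at which 1 of the 4 values shown sits.

Still open, from the compounds shown here alone, is whether any substituent on the phenyl ring is tolerated, such as a methoxy group or an amine. Also open, going by these compounds, is how a longer chain, such as phenethyl, compares with benzyl on this nitrogen.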